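The source may hold more compounds than are shown below. What is called first, only, known or untested is meant among the compounds shown, and "the series" means these compounds.

Two compounds frame this account. For compound 1 `NC(=O)c1[nH]cnc1-c1ccccc1` the entry in an ADME assay on Jurkat cells (Homo sapiens) for cytotoxicity, read by XTT assay (a higher number here means that more compound is tolerated, a lower number that less compound is tolerated), reads "not determined" (no result reported), so it offers no number to compare. Compound 2 `NC(=O)c1sc(N)nc1-c1cccc(C(=O)c2ccccc2)c1` carries a benzoyl-bearing phenyl group and an amino group on its five-membered ring. In this assay compound 2 gives > 312000 nM, which is a limit of the assay and not a number. For the measured compounds named here, compound 2 therefore has no exact value, and no other compound has been measured against it.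

Compound 3 `NC(=O)c1scnc1-c1cccc(C(=O)c2ccccc2)c1` differs from compound 2 in one place, with hydrogen in place of amino on an aromatic carbon, next to the ring nitrogen and next to the ring sulfur: hydrogen in place of amino on an aromatic carbon. No measured step between any two of these compounds is available as a guide. The expected change an at least 1.0-fold lower number from compound 2 to compound 3 (0.01 log units; that floor lies within the scatter) is therefore no larger than the usual scatter, in neither direction. The assay may well report only a limit again. For compound 3 the estimated value in this assay is 300000 nM, with an expected range from 100000 nM to 400000 nM.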

Compound 3, half-maximal cytotoxic concentration: > 312000 nM
Compound 3: no number, only a limit; the forecaster's own chance of this, stated with the estimate: 65%; middle value at least 1.0-fold (0.01 log units) from the limit.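

No step can be read from compound 2 to compound 3 in this assay because each of the two entries is a limit of the assay and not a number: the limit of > 312000 nM in this assay, at which 2 of the 3 values shown sit. The compounds shown leave open whether hydrogen in place of amino changes the tolerated concentration at all, and in which direction.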